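Adding a second chloro to the anilino ring of compound 2

A few compounds are considered here, and "the series" means these few. Any claim that something is new, unique, unknown or untested is made for them only; others in the source may bear on it.

Compound 1 `O=C(CSc1nc(Nc2ccccc2)c2ccccc2n1)Nc1ccc(Cl)c(Cl)c1`: 37900 nM
Compound 2 `C=CC(=O)Nc1cccc(NC(=O)CSc2nc(Nc3cccc(Cl)c3)c3ccccc3n2)c1`: 7830 nM

In a functional assay on MGC-803 cells (Homo sapiens) for inhibition, read by MTT assay, with a stated time of 72 h (on this read-out higher numbers stand for weaker inhibition and lower numbers for stronger inhibition), compound 2 gives the lower of the two numbers, and compound 1 stands well beyond the scatter above it. Compound 3 `C=CC(=O)Nc1cccc(NC(=O)CSc2nc(Nc3ccc(Cl)c(Cl)c3)c3ccccc3n2)c1` has not yet been tested. It differs from compound 2 in one place: chloro in place of hydrogen on an aromatic carbon. Compound 1 carries the same 3,4-dichlorophenyl, but on the amide rather than the amino side, so it offers no direct guide. A step of a 1.2-fold lower number from compound 2 to compound 3 (0.08 log units; within the scatter) is expected, within the scatter. Compound 3 is estimated at 6500 nM, between 2000 nM and 20000 nM.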

Compound 3, half-maximal inhibitory concentration: > 50000 nM
Compound 3: no number, only a limit; the forecaster's own chance of this, stated with the estimate: 3%; middle value at least 7.6-fold (0.88 log units) away from the limit.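

In this assay, going from 3-chlorophenyl to 3,4-dichlorophenyl brings an at least 6.3-fold higher number from compound 2 to compound 3 (0.80 log units; beyond the scatter), so a chloro ortho to a chloro group and para to a large group is not tolerated here as the hydrogen is. The earlier compounds shown here offered no step at this position, and this first one runs towards weaker inhibition. Compound 3 gives only a limit of the assay, not a number: the limit of > 50000 nM in this assay, at which 1 of the 3 values shown sits.

From the compounds shown here alone, how far compound 3 lies past that limit stays open. So does whether a fluoro or a methoxy in place of this chloro would fare the same.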